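The source may report more compounds than this note shows. Statements on the series, on what has been measured and on what is new or still open speak of the compounds shown alone.

In a functional assay on HCT-116 cells (Homo sapiens) for inhibition, read by MTT assay, with a stated time of 72 h (on this read-out higher numbers stand for weaker inhibition of growth and lower numbers for stronger inhibition of growth), the two measured compounds read as follows.

Compound 1 `O=C1COc2ccc(-n3cc(C[C@H](O)COCCOC[C@@H](O)Cc4ccc(-c5ccccc5)cc4)nn3)cc2N1` gives 42500 nM in this series.
Compound 2 `O[C@H](COCCOC[C@@H](O)Cc1cn(-c2cncnc2)nn1)Cc1ccc(-c2ccccc2)cc1` gives > 100000 nM in this series.

The second entry is a limit of the assay and not a number. For compound 2 only that limit is known (the limit of > 100000 nM in this assay, at which 1 of the 2 values shown sits).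

Compound 3 `O[C@H](COCCOC[C@@H](O)Cc1c[nH]nn1)Cc1ccc(-c2ccccc2)cc1` follows from compound 2 by one change, (hydrogen in place of pyrimidin-5-yl on an aromatic nitrogen), which is hydrogen in place of pyrimidin-5-yl on an aromatic nitrogen.

Among the compounds with values here, one measured step bears on this. It also replaces the group on an aromatic nitrogen by a smaller one. That step is an at least 2.3-fold higher number from compound 1 to compound 2 (0.37 log units; beyond the scatter), beyond the scatter, and its true size is open since one end of it is a limit. Within the data shown here, no measured compound carries hydrogen at this place, so the evidence is thin. A return to stronger inhibition is not expected in this assay, and a further rise would probably stay hidden at the limit.

The estimated change is small in size and is given as a step that the limit leaves unreadable from compound 2 to compound 3 ( expected, not measured ).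

For compound 3 the expected value is 110000 nM, with an estimated range from 45000 nM to 250000 nM ( an expectation only ).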

Compound 3, concentration for 50% growth inhibition: > 100000 nM
Compound 3 was reported as a limit (the forecaster's own chance of this, stated with the estimate: 70%); the middle value does not contradict the limit.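

In this assay, hydrogen on the aromatic nitrogen gives no readable growth inhibition, and the entry for compound 3 is a limit of the assay and not a number: the limit of > 100000 nM in this assay, at which 2 of the 3 values shown sit.

Against the only compound with a measured number, the change gives an at least 2.3-fold higher number from compound 1 to compound 3 (0.37 log units; beyond the scatter), so among the three compounds shown, only the large group of compound 1 on this nitrogen goes with a reading inside the range of the assay. On these data alone, the step between compound 2 and compound 3 cannot be read, as both ends are limits, so it remains unknown whether pyrimidin-5-yl and hydrogen differ at all at this place.

The compounds shown leave open whether the reading of compound 1 depends on its particular group or would also appear with a simpler one on the same nitrogen, such as a plain phenyl or a benzyl group. They also leave open how a group with an amine or a carboxylic acid would read there, and whether any such group could bring a number well below that of compound 1.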